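Swapping a Hydroxyalkylamine for an Acetamide on the Core

A few compounds are considered here, and "the series" means these few. Any claim that something is new, unique, unknown or untested is made for them only; others in the source may bear on it.

In an assay on isolated protein for inhibition of serine/threonine-protein kinase TNNI3K (Homo sapiens) (on this read-out higher numbers stand for weaker inhibition and lower numbers for stronger inhibition), compound 1 `Cc1cc(Oc2ccc(NC(=O)Nc3cccc(C(F)(F)F)c3)cc2)ncn1` gives 160 nM, and compound 2 `CC(C)(O)CNc1cc(Oc2ccc(NC(=O)Nc3cccc(C(F)(F)F)c3)cc2)ncn1` gives 40 nM, the lower of the two numbers; the step of a 4.0-fold lower number from compound 1 to compound 2 (0.60 log units; beyond the scatter) was modest. Compound 3 `CC(=O)Nc1cc(Oc2ccc(NC(=O)Nc3cccc(C(F)(F)F)c3)cc2)ncn1` differs from compound 2 by acetyl in place of 2-hydroxy-2-methylpropyl on a nitrogen on an aromatic ring, so the chain on the shared core is replaced while the aromatic nitrogen stays. Among the measured compounds shown here, only the step from compound 1 to compound 2 bears on this change, and it shows that this position shifts inhibition by a modest amount when the group there is swapped. Compound 3 is therefore expected to land between the two measured numbers, a step of a 2.5-fold higher number from compound 2 to compound 3 (0.40 log units; beyond the scatter), estimated at 100 nM with a range from 30 nM to 320 nM.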

Compound 3, half-maximal inhibitory concentration: 20 nM
Compound 3: the middle estimate sits 5.0-fold (0.70 log units) above what was measured, outside the stated range (below it).
By their numbers in this assay, from the lowest: compounds 3 and 2 (each within the scatter of the next); then compound 1.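

In this assay, acetyl in place of 2-hydroxy-2-methylpropyl on the nitrogen gives a 2.0-fold lower number from compound 2 to compound 3 (0.30 log units; within the scatter) and so leaves the two groups indistinguishable, even though acetyl counts no hydrogen-bond donor. Acetamido in place of methyl gives an 8.0-fold lower number from compound 1 to compound 3 (0.90 log units; beyond the scatter) and so shows that a second, quite different nitrogen-linked group also gives a lower number than methyl on this aromatic carbon. No measurement shown gives a reason for this. On these data alone, whether a plain amine or a longer amide chain would give a similar number remains open.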